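Methoxy to Fluoro at Two Places: Three Measured, One Open

The compounds below may be only part of what the source reports. "The series", "measured", "known", "first", "only" and "open" are said of these compounds alone.

Compound 1 `COc1ccc(-c2cn3ccnc3c(-c3ccc4ncn(C5CCCCC5)c4c3)n2)cc1` gives 83.2% in a functional assay on KM12 cells (Homo sapiens) for inhibition, read by sulforhodamine B assay, with a stated time of 48 h, tested at 10 uM; on this read-out lower numbers stand for less inhibition and higher numbers for more inhibition at the one concentration tested (going by the name of the read-out).
Compound 2 `Fc1ccc(-c2cn3ccnc3c(-c3ccc4ncn(C5CCCCC5)c4c3)n2)cc1` gives 3.49%.
Compound 3 `COc1ccccc1-c1cn2ccnc2c(-c2ccc3ncn(C4CCCCC4)c3c2)n1` gives 3.58%.

Compound 2 differs from compound 1 by fluoro in place of methoxy on an aromatic carbon, and the step is a number 79.7 percentage points lower from compound 1 to compound 2 (beyond the scatter). Compound 3 differs from compound 1 by 2-methoxyphenyl in place of 4-methoxyphenyl on an aromatic carbon, with a step of a number 79.6 percentage points lower from compound 1 to compound 3 (beyond the scatter). Between compound 2 and compound 3 the step is a number 0.1 percentage points higher from compound 2 to compound 3 (within the scatter).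

Compound 4 `Fc1ccccc1-c1cn2ccnc2c(-c2ccc3ncn(C4CCCCC4)c3c2)n1` differs from compound 3 by fluoro in place of methoxy on an aromatic carbon. This is the same kind of change as from compound 1 to compound 2, but not the same: there the place was para to a large group, here it is ortho to a large group. Since compound 3 already gives 3.58%, only a small step is expected, a number 1.4 percentage points higher from compound 3 to compound 4 (within the scatter). Compound 4 is estimated at 5%, expected between -8% and 25%.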

Compound 4, a percentage reported as inhibition, at one concentration (the size of the read-out at that concentration, not a potency): 2.45%
Estimate against measurement, compound 4: 2.6 percentage points above; low and high end bracket the measured number.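

In this assay, fluoro in place of methoxy does not carry over evenly from one core to the other: the same change on two cores in this assay, a number 79.7 percentage points lower (beyond the scatter) from compound 1 to compound 2 and a number 1.1 percentage points lower (within the scatter) from compound 3 to compound 4, 78.6 percentage points apart, beyond the scatter of two such steps.
On the 2-methoxyphenyl compounds the change is a number 1.1 percentage points lower from compound 3 to compound 4 (within the scatter), the shift from 4-fluorophenyl to 2-fluorophenyl is a number 1 percentage points lower from compound 2 to compound 4 (within the scatter), and the comparison with the 4-methoxyphenyl compound is a number 80.8 percentage points lower from compound 1 to compound 4 (beyond the scatter). Only compound 1 stands high, so the pairs do not show how this change acts on a second compound that starts high.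

As far as these compounds go, it remains open whether the high number of compound 1 needs methoxy itself. An ethoxy group, a hydroxyl or a dimethylamino group on the same phenyl would test this.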